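Replacing the 3-fluoro-4-methylphenyl Group of Compound 2

The source may hold more compounds than are shown below. What is called first, only, known or untested is meant among the compounds shown, and "the series" means these compounds.

In an ADME assay for permeability, using PAMPA, with a stated time of 4 h (a lower number here means that the compound crosses the layer more slowly, a higher number that the compound crosses the layer faster), compound 2 `Cc1ccc(Oc2ccc3nc(COc4cccc(C(=O)O)c4)n(C)c3n2)cc1F` gives 14.8 10^-6 cm/s. Compound 3 `Cc1cc(C)cc(Oc2ccc3nc(COc4cccc(C(=O)O)c4)n(C)c3n2)c1` gives 17.4 10^-6 cm/s, and compound 1 `Cn1c(COc2cccc(C(=O)O)c2)nc2ccc(Oc3ccc(Cl)c(F)c3)nc21` gives 25.6 10^-6 cm/s. These three values lie within the scatter of one another, so compound 2 holds no distinct place among them.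

Compound 4 `Cn1c(COc2cccc(C(=O)O)c2)nc2ccc(Oc3ccc4c(c3)CCC4)nc21`, still unmeasured, differs from compound 2 in the group on the oxygen: 2,3-dihydro-1H-inden-5-yl in place of 3-fluoro-4-methylphenyl on an oxygen on an aromatic ring. Three measured steps alter that same group. The closest is a 1.2-fold higher number from compound 2 to compound 3 (0.07 log units; within the scatter), where 3,5-dimethylphenyl takes the place of 3-fluoro-4-methylphenyl. The other two are a 1.7-fold lower number from compound 1 to compound 2 (0.24 log units; within the scatter) and a 1.5-fold lower number from compound 1 to compound 3 (0.17 log units; within the scatter). Within the data shown here, none of the measured compounds carries 2,3-dihydro-1H-inden-5-yl, so the data offer no direct precedent for it. With all three steps inside the scatter, no shift beyond the scatter is expected in this assay. The expected change is a 1.3-fold higher number from compound 2 to compound 4 (0.11 log units; within the scatter). For compound 4 the estimate is 19 10^-6 cm/s, with an expected range from 10 10^-6 cm/s to 34 10^-6 cm/s.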

Compound 4, apparent permeability: 31.5 10^-6 cm/s
For compound 4 the middle estimate is 1.7-fold (0.22 log units) below the measured one, within the range that was stated.
By their numbers in this assay, from the lowest: compounds 2, 3, 1 and 4 (each within the scatter of the next, the first and the last beyond it).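

In this assay the group on the oxygen now yields its first step beyond the scatter, a modest one, when 2,3-dihydro-1H-inden-5-yl replaces 3-fluoro-4-methylphenyl (a 2.1-fold higher number from compound 2 to compound 4 (0.33 log units; beyond the scatter)). The same group stays within the scatter against the other two aryl groups (a 1.8-fold higher number from compound 3 to compound 4 (0.26 log units; within the scatter); a 1.2-fold higher number from compound 1 to compound 4 (0.09 log units; within the scatter)), so compound 4 stands apart only from compound 2 and not from compound 1 or compound 3. Nothing available accounts for this step.

On these data alone, whether the step persists with a hydroxyl or an amine on the five-membered non-aromatic ring, or with a cyclohexyl or pyridyl group on the oxygen, remains open. As far as these compounds go, all four compounds share the rest of their structure, so it is also open whether the step would carry over to another core.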